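Replacing the Carboxyethyl Group with a Methoxycarbonyl Group

The compounds below may be only part of what the source reports. "The series", "measured", "known", "first", "only" and "open" are said of these compounds alone.

Measured compounds:
compound 1 `CCNC(=O)NC1=CS(=O)(=O)O[C@@]12[C@@H](CO[Si](C)(C)C(C)(C)C)O[C@@H](n1cc(C)c(=O)n(C)c1=O)[C@@H]2O[Si](C)(C)C(C)(C)C`; in a functional assay on HEL cells (Homo sapiens) (a higher number here means that more compound is tolerated, a lower number that less compound is tolerated), compound 1 gives 10000 nM
compound 2 `Cc1cn([C@@H]2O[C@H](CO[Si](C)(C)C(C)(C)C)[C@@]3(OS(=O)(=O)C=C3NCCC(=O)O)[C@H]2O[Si](C)(C)C(C)(C)C)c(=O)n(C)c1=O`; compound 2 gives 34000 nM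
compound 3 `Cc1cn([C@@H]2O[C@@H]3COC(=O)[C@]3(OS(C)(=O)=O)[C@H]2O)c(=O)[nH]c1=O`; compound 3 gives >= 36000 nM, which is a limit of the assay rather than a number

Compound 2 holds the highest of the two numbers; the nearest is compound 1, from which it is separated by a 3.4-fold higher number from compound 1 to compound 2 (0.53 log units; beyond the scatter). Compound 4 `COC(=O)NC1=CS(=O)(=O)O[C@@]12[C@@H](CO[Si](C)(C)C(C)(C)C)O[C@@H](n1cc(C)c(=O)n(C)c1=O)[C@@H]2O[Si](C)(C)C(C)(C)C` differs from compound 2 by methoxycarbonyl in place of 2-carboxyethyl on an amine nitrogen. Going by the values given here, only that one measured step bears on this change, and it ran upward when the ethylcarbamoyl group was replaced; a methoxycarbonyl group, like the ethylcarbamoyl group of compound 1, attaches through a carbonyl to the amine nitrogen, so the step is expected to run back downward, roughly a 2.6-fold lower number from compound 2 to compound 4 (0.42 log units; beyond the scatter). Compound 4 is therefore estimated at 13000 nM, within a range of 5000 nM to 36000 nM.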

Compound 4, half-maximal cytotoxic concentration: > 200000 nM
Compound 4: only a limit was reported; the forecaster's own chance of this, stated with the estimate: 15%; at least 15-fold (1.18 log units) between middle value and limit.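

At this amine nitrogen, a carbonyl link alone does not set the number: methoxy in place of ethylamino on that carbonyl carbon gives an at least 20-fold higher number from compound 1 to compound 4 (1.30 log units; beyond the scatter). Methoxycarbonyl also tops 2-carboxyethyl, with an at least 5.8-fold higher number from compound 2 to compound 4 (0.76 log units; beyond the scatter). Both steps give only a minimum size, because compound 4 reached a limit of the assay rather than a number: the limit of > 200000 nM in this assay, at which 1 of the 4 values shown sits.

Still open, as far as these compounds go, is how far the number of compound 4 really lies beyond that limit. Also open, from the compounds shown here alone, is whether an ethoxycarbonyl or an acetyl group on this nitrogen would give a number as high.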